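Acylating the aniline nitrogen of a chalcone: two steps, then a third

The compounds below may be only part of what the source reports. "The series", "measured", "known", "first", "only" and "open" are said of these compounds alone.

Measured so far:
Compound 1, `COc1cc(/C=C/C(=O)c2cccc(NC(=O)c3c(Cl)cccc3Cl)c2)ccc1O`: 1.58 ug/mL
Compound 2, `COc1cc(/C=C/C(=O)c2cccc(NC(=O)c3cc(Cl)cc(Cl)c3)c2)ccc1O`: 4.83 ug/mL
Compound 3, `COc1cc(/C=C/C(=O)c2cccc(N)c2)ccc1O`: 11.5 ug/mL

The three compounds share a chalcone core carrying a free or acylated amino group on one aromatic ring. Compound 3, the free amine, stands at the highest number of the three in a functional assay on B16 cells (Mus musculus) for inhibition; a lower number here means a stronger inhibitor, a higher number a weaker inhibitor; compound 2 lies nearest to it, compound 1 furthest. Both acylated compounds fall below it: a 7.3-fold higher number from compound 1 to compound 3 (0.86 log units; beyond the scatter) and a 2.4-fold higher number from compound 2 to compound 3 (0.38 log units; beyond the scatter), and between the two acyl groups themselves a 3.1-fold higher number from compound 1 to compound 2 (0.49 log units; beyond the scatter).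

Compound 4, `CCOC(=O)C(=O)Nc1cccc(C(=O)/C=C/c2ccc(O)c(OC)c2)c1`, is the next compound to be tested. It differs from compound 3 in one place: (ethoxycarbonyl)carbonyl in place of hydrogen on a nitrogen on an aromatic ring. Like compounds 1 and 2, it carries an acyl group on the ring nitrogen, but the group is a short open chain rather than a dichlorophenyl ring, so the two measured acylation steps are the only guide, and they do not match the new group closely. Both steps moved the number downward, one modestly, one more strongly. The estimate for compound 4 is therefore a modest lowering, a 2.3-fold lower number from compound 3 to compound 4 (0.36 log units; beyond the scatter), giving an expected value of 5 ug/mL with a likely range from 1.8 ug/mL to 14 ug/mL in this assay.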

Compound 4, half-maximal inhibitory concentration: 7.03 ug/mL
The estimate for compound 4 lay 1.4-fold (0.15 log units) below the measured number, within the range that was stated.
By their numbers in this assay, from the lowest: compound 1; then compounds 2, 4 and 3 (each within the scatter of the next, the first and the last beyond it).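

In this assay, placing an acyl group on the nitrogen on the aromatic ring does not by itself give a step beyond the scatter: with (ethoxycarbonyl)carbonyl the reading is a 1.6-fold lower number from compound 3 to compound 4 (0.21 log units; within the scatter), whereas the steps from compounds 1 and 2 to the free amine compound 3 both lie beyond it. With the acylated nitrogen held constant, the open-chain ethoxycarbonyl group and the ringed 3,5-dichlorophenyl group cannot be told apart, at a 1.5-fold higher number from compound 2 to compound 4 (0.16 log units; within the scatter), while the change from 2,6-dichlorophenyl is a 4.4-fold higher number from compound 1 to compound 4 (0.65 log units; beyond the scatter), so among these three compounds, having a ring on the carbonyl carbon is not by itself what sets compound 1 apart, since compound 2 carries one as well. Nothing available here accounts for these steps.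

The compounds shown leave open how a carboxylic acid in place of the ethyl ester, or a longer chain on the same nitrogen, would read. They also leave open whether an unsubstituted phenyl on the carbonyl carbon would fall with compound 1 or with compounds 2 and 4.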